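Compound 2 to compound 3: losing the methoxy

A few compounds are considered here, and "the series" means these few. Any claim that something is new, unique, unknown or untested is made for them only; others in the source may bear on it.

In a functional assay on HEp-2 cells (Homo sapiens) for antiproliferative activity, read by MTT assay, with a stated time of 72 h (on this read-out higher numbers stand for weaker inhibition and lower numbers for stronger inhibition), compound 1 `NC(=S)N/N=C/c1ccccc1O` is recorded only as a limit, >= 5000 nM, and not as a number. Going by the values given here, compound 2 `COc1cccc(/C=N/NC(=S)Nc2ccccc2)c1O` gives 1600 nM, the only number so far, so it has no measured neighbour for a numerical comparison.

Compound 3 `Oc1ccccc1/C=N/NC(=S)Nc1ccccc1` follows from compound 2 by one change: hydrogen in place of methoxy on an aromatic carbon, ortho to a hydroxy group and meta to a large group (hydrogen in place of methoxy on an aromatic carbon). The hydroxy group and the rest of compound 2 stay as they are.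

Among the compounds with values here, no measured pair isolates this change, so its size in this assay can only be judged loosely. A small step is expected, most likely none beyond the scatter, with a slight lean towards weaker inhibition. The anchor for this expectation is compound 2 at 1600 nM. The expected step is a 1.3-fold higher number from compound 2 to compound 3 (0.10 log units; within the scatter).

For compound 3 the estimated value is 2000 nM, with an expected range of 700 nM to 6000 nM.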

Compound 3, half-maximal inhibitory concentration: 2400 nM
The estimate for compound 3 lay 1.2-fold (0.08 log units) below the measured number; the range from low to high includes it.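

In this assay, hydrogen in place of methoxy on this aromatic carbon, ortho to a hydroxy group and meta to a large group, gives a 1.5-fold higher number from compound 2 to compound 3 (0.18 log units; within the scatter). Going by these compounds alone, this is the first measured reading of the position, and it shows that the methoxy can go without the number leaving the usual scatter, so the activity seen in compound 2 does not depend on that group. Phenyl in place of hydrogen on the amide-type nitrogen gives an at least 2.0-fold lower number from compound 1 to compound 3 (0.31 log units; beyond the scatter), the first sign in the series that this nitrogen is a more sensitive place than the aromatic carbon, though the step is only a bound, since compound 1 is recorded as a limit and not as a number: the limit of >= 5000 nM in this assay, at which 1 of the 3 values shown sits.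

Still open is whether other groups on this aromatic carbon, such as an amine, a carboxylic acid or a longer chain like ethoxy, would move the number beyond the scatter, and whether the hydroxy group itself is needed, since no pair shown changes it. As far as these compounds go, the full size of the phenyl step also stays open, as does the effect of a benzyl or a substituted phenyl on that nitrogen.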